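Shifting a methyl on the sulfonamide aryl group

This account rests on a few compounds, and the source may have more. Where it says the series, first, only, none or still open, it means among the compounds named here.

In a functional assay (Homo sapiens) for antiproliferative activity, read by sulforhodamine B assay, with a stated time of 48 h (on this read-out lower numbers stand for stronger inhibition and higher numbers for weaker inhibition), compound 1 `CCc1cccc(NS(=O)(=O)c2ccc(N3CCNC3=O)cc2)c1` gives 270 nM, compound 2 `O=C1NCCN1c1ccc(S(=O)(=O)Nc2cccc(Br)c2)cc1` gives 270 nM and compound 3 `Cc1cc(C)cc(NS(=O)(=O)c2ccc(N3CCNC3=O)cc2)c1` gives 260 nM. Compound 3 therefore stands within the scatter of the other two. Compound 4 `Cc1ccc(C)c(NS(=O)(=O)c2ccc(N3CCNC3=O)cc2)c1` differs from compound 3 as follows: 2,5-dimethylphenyl in place of 3,5-dimethylphenyl on a sulfonamide nitrogen. The measured steps that bear on this are a 1.0-fold lower number from compound 1 to compound 3 (0.02 log units; within the scatter) and a 1.0-fold lower number from compound 2 to compound 3 (0.02 log units; within the scatter), along with no change at the digits printed from compound 1 to compound 2 (within the scatter), and all are within the scatter. Going by the values given here, no measured compound carries the 2,5-dimethylphenyl group, so the range stays wide. The expected step is a 1.2-fold higher number from compound 3 to compound 4 (0.09 log units; within the scatter), with no change beyond the scatter anticipated in this assay. For compound 4 the estimate is 320 nM, with an expected range of 110 nM to 950 nM.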

Compound 4, half-maximal inhibitory concentration: 86 nM
Compound 4: middle estimate off by 3.7-fold (0.57 log units), on the high side; the measured number lies below the stated range.
By their numbers in this assay, from the lowest: compound 4; then compounds 3, 1 and 2 (each within the scatter of the next).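

In this assay, rearranging the same atoms from 3,5-dimethylphenyl to 2,5-dimethylphenyl on the sulfonamide nitrogen gives a 3.0-fold lower number from compound 3 to compound 4 (0.48 log units; beyond the scatter), so this position responds to methyl placement, which the earlier aryl changes, all within the scatter, did not reveal. The 2,5-dimethylphenyl group also stands apart from the 3-bromophenyl and 3-ethylphenyl groups, with a 3.1-fold lower number from compound 2 to compound 4 (0.50 log units; beyond the scatter) and a 3.1-fold lower number from compound 1 to compound 4 (0.50 log units; beyond the scatter). No measurement shown accounts for these steps.

Going by these compounds, whether a methoxy group, a chlorine or an amine could replace either methyl of the 2,5-dimethylphenyl group and keep this number remains open.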